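A few compounds are considered here, and "the series" means these few. Any claim that something is new, unique, unknown or untested is made for them only; others in the source may bear on it.

Measured so far in an ADME assay on microsomes from liver (Mus musculus) for metabolic stability; on this read-out higher numbers stand for a longer-lived compound and lower numbers for a shorter-lived compound:
- compound 1, `NC(=O)CNC(=O)C[C@H]1CC[C@]2(CC1)OO[C@]1(O2)C2CC3CC(C2)CC1C3`: 2.07 h
- compound 2, `NCCNC(=O)C[C@H]1CC[C@]2(CC1)OO[C@]1(O2)C2CC3CC(C2)CC1C3`: 1.07 h
- compound 3, `NC(=O)CNC(=O)C[C@@H]1CCC[C@]2(C1)OOC1(O2)C2CC3CC(C2)CC1C3`: 0.622 h

Compounds 1 and 2 share one core; compound 3 carries a different core, and the difference between the two cores is not broken down here. Within the first core the change aminomethyl in place of carbamoyl on a saturated chain carbon bound to an amide-type nitrogen gave a 1.9-fold lower number from compound 1 to compound 2 (0.29 log units; within the scatter). Compound 3 has the lowest number of the three in this assay, beyond the scatter from compound 1 but within it from compound 2.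

Compound 4, `NCCNC(=O)C[C@@H]1CCC[C@]2(C1)OOC1(O2)C2CC3CC(C2)CC1C3`, is the unmeasured partner of compound 3 and carries the same change, (aminomethyl in place of carbamoyl on a saturated chain carbon bound to an amide-type nitrogen), at the same place as seen between compound 1 and compound 2. For the measured compounds named here, as the only precedent for this change is a 1.9-fold lower number from compound 1 to compound 2 (0.29 log units; within the scatter), a step of similar size is expected from compound 3 to compound 4, namely a 1.9-fold lower number from compound 3 to compound 4 (0.28 log units; within the scatter). Compound 4 is therefore estimated at 0.33 h in this assay, with a likely range from 0.15 h to 0.75 h; this rests on a single precedent and on the value of compound 3, 0.622 h, alone.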

Compound 4, half-life: 1.41 h
For compound 4 the middle estimate is 4.3-fold (0.63 log units) below the measured one; the measured number lies above the stated range.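

In this assay, the same replacement of carbamoyl by aminomethyl gave a 2.3-fold higher number from compound 3 to compound 4 (0.36 log units; beyond the scatter), and the result on one core did not carry over to the other: the same change on two cores in this assay, a 1.9-fold lower number (0.29 log units; within the scatter) from compound 1 to compound 2 and a 2.3-fold higher number (0.36 log units; beyond the scatter) from compound 3 to compound 4, 4.4-fold (0.64 log units) apart, beyond the scatter of two such steps

For these two pairs, the outcome of the change depends on the core, so a step read on one core is a poor guide to the step on the other. For the compounds shown here, the data do not show which feature of the cores sets this outcome, and with only two pairs they give no general rule for the series.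

The compounds shown leave open how a carboxylic acid or a longer chain ending in an amine would behave in place of carbamoyl on each core. A further core carrying both carbamoyl and aminomethyl would show how often the step differs from core to core.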